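From thiophen-2-yl to 4-carboxycyclohexyl on a shared core

The source may hold more compounds than are shown below. What is called first, only, known or untested is meant among the compounds shown, and "the series" means these compounds.

In a functional assay on U-373MG ATCC cells (Homo sapiens) for cytotoxicity, read by MTT assay (a lower number here means a stronger inhibitor, a higher number a weaker inhibitor), three compounds with a shared core have been measured. Compound 1 `Oc1ccc(CN(Cc2ccccc2C(F)(F)F)Cc2ccc(O)c3ncccc23)c2cccnc12` gives 78 nM, compound 3 `Oc1ccc(CN(Cc2cccs2)Cc2ccc(O)c3ncccc23)c2cccnc12` gives 85 nM, and compound 2 `Oc1ccc(CN(Cc2cccc(I)c2)Cc2ccc(O)c3ncccc23)c2cccnc12` gives 5600 nM. Compound 3 therefore sits level with compound 1 and far from compound 2. The two steps that place it are a 1.1-fold higher number from compound 1 to compound 3 (0.04 log units; within the scatter) and a 66-fold lower number from compound 2 to compound 3 (1.82 log units; beyond the scatter).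

The next molecule, compound 4 `O=C(O)C1CCC(CN(Cc2ccc(O)c3ncccc23)Cc2ccc(O)c3ncccc23)CC1`, keeps the core and alters one group: 4-carboxycyclohexyl in place of thiophen-2-yl on a saturated chain carbon bound to an amine nitrogen. Here 4-carboxycyclohexyl takes the place of thiophen-2-yl on a saturated chain carbon bound to an amine nitrogen. Earlier changes at this same place show two outcomes. One swap left the number unchanged within the scatter, a 1.1-fold higher number from compound 1 to compound 3 (0.04 log units; within the scatter), while another produced a large move, a 72-fold higher number from compound 1 to compound 2 (1.86 log units; beyond the scatter). Among the compounds with values here, no measured compound carries a group like 4-carboxycyclohexyl, so the data offer only an indirect guide. The one large move away from the low pair went towards a higher number, so a rise of moderate size is expected, and the estimated step is an 18-fold higher number from compound 3 to compound 4 (1.25 log units; beyond the scatter). For compound 4 the estimated value is 1500 nM, with an expected range from 150 nM to 15000 nM.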

Compound 4, half-maximal inhibitory concentration: 3730 nM
Compound 4: the middle estimate sits 2.5-fold (0.40 log units) below what was measured; the range from low to high includes it.
By their numbers in this assay, from the lowest: compounds 1 and 3 (each within the scatter of the next); then compounds 4 and 2 (each within the scatter of the next).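

In this assay, within the data shown here, the change to 4-carboxycyclohexyl is the first at this position to leave a thiophen-2-yl compound in the high range, with a 44-fold higher number from compound 3 to compound 4 (1.64 log units; beyond the scatter) and, against the 2-(trifluoromethyl)phenyl compound, a 48-fold higher number from compound 1 to compound 4 (1.68 log units; beyond the scatter) as the second large step. Compound 4 also stands level with compound 2, at a 1.5-fold lower number from compound 2 to compound 4 (0.18 log units; within the scatter) as the step between them, so a high number here is no longer tied to 3-iodophenyl alone and now comes with a six-membered non-aromatic ring of carbon only as well, while compound 1 and compound 3 remain the two low exceptions. No measurement shown here gives a reason for any of these steps.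

Compound 4 brings in the cyclohexane ring and the carboxylic acid together, so the compounds shown leave open which of the two goes with the higher number. A plain cyclohexyl group, a phenyl ring carrying a carboxylic acid, or the methyl ester of compound 4 would each help to separate the ring from the acid at this position.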